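Sulfonamide capping of the aromatic amine in the series

A few compounds are considered here, and "the series" means these few. Any claim that something is new, unique, unknown or untested is made for them only; others in the source may bear on it.

Compound 2 `Nc1ccc2c(c1)/C(=C(/Nc1ccc(CN3CCCCC3)cc1)c1ccccc1)C(=O)N2` stands at the edge of what an ADME assay on HepG2 cells (Homo sapiens) for cytotoxicity, read by MTT assay, with a stated time of 48 h (on this read-out higher numbers stand for lower toxicity in this test and lower numbers for higher toxicity in this test), resolves: compound 2 gives > 6 uM, which is a limit of the assay and not a number (the limit of > 6 uM in this assay, at which 1 of the 3 values shown sits). For the measured compounds named here, compound 3 `CC(=O)N1C(=O)/C(=C(\Nc2ccc(CN3CCCCC3)cc2)c2ccccc2)c2cc(N)ccc21` gives 1.81 uM, and the step of an at least 3.3-fold lower number from compound 2 to compound 3 (0.52 log units; beyond the scatter), acetyl in place of hydrogen on an amide-type nitrogen in a ring, is the only single-site change measured so far; it runs downward. Compound 1 `CCS(=O)(=O)Nc1ccc2c(c1)/C(=C/Nc1ccc(CN3CCCCC3)cc1)C(=O)N2` gives 5 uM; it differs from compound 2 in more than one place, so its value stands beside that of compound 2 without a computed step. Compound 4 `O=C1Nc2ccc(NS(=O)(=O)c3ccccc3)cc2/C1=C(/Nc1ccc(CN2CCCCC2)cc1)c1ccccc1` is not yet measured and differs from compound 2 by phenylsulfonyl in place of hydrogen on a nitrogen on an aromatic ring. Going by the values given here, no measured step matches this change; the acetyl step is the nearest comparison, yet it concerns a different group on a different nitrogen. A small step of an at least 1.2-fold lower number from compound 2 to compound 4 (0.07 log units; that floor lies within the scatter) is expected, staying within the scatter of where compound 2 sits. Compound 4 is therefore estimated at 5 uM, in the range 2 uM to 12 uM, with a fair chance that this assay again returns only a limit.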

Compound 4, half-maximal toxic concentration: 3.29 uM
Compound 4: the middle estimate sits 1.5-fold (0.18 log units) above what was measured; low and high end bracket the measured number.
By their numbers in this assay, from the lowest: compounds 3, 4 and 1 (each within the scatter of the next, the first and the last beyond it). At a limit, above all of these: compound 2.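

For the compounds shown here, this is the first measured change on the nitrogen on an aromatic ring, and in this assay compound 4 gives a number, 3.29 uM, so phenylsulfonyl at this place brings the reading inside the range of the assay. The change from amino to (phenylsulfonyl)amino reads as an at least 1.8-fold lower number from compound 2 to compound 4 (0.26 log units; that floor lies within the scatter); with that floor, a real drop is not established, and the size of the step stays undetermined. Compound 2 remains a limit of the assay and not a number: the limit of > 6 uM in this assay, at which 1 of the 4 values shown sits.

The compounds shown leave open whether a smaller sulfonyl group such as methylsulfonyl, on the core of compound 4, would read the same as phenylsulfonyl. Also open, going by these compounds, is whether an amine or a carboxylic acid on the phenyl ring of the phenylsulfonyl group would move the number in this assay.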